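A few compounds are considered here, and "the series" means these few. Any claim that something is new, unique, unknown or untested is made for them only; others in the source may bear on it.

Compound 1, `CC#CC(CC(=O)O)c1ccc(OCc2cnc(C(=O)N3CCc4ccccc4C3)s2)cc1`: in a functional assay on HEK293 cells for agonist activity at Free fatty acid receptor 1 (Homo sapiens), read by fluorescence and calcium flux (on this read-out lower numbers stand for an effect already at smaller amounts and higher numbers for an effect only at larger amounts of compound), compound 1 gives 531 nM
Compound 2, `CC#CC(CC(=O)O)c1ccc(OCc2ccc(C(=O)N3CCc4ccccc4C3)o2)cc1`: in this assay compound 2 gives 50 nM
Compound 3, `CC#CC(CC(=O)O)c1ccc(OCc2cnc(C(=O)NC3CCCc4ccccc43)s2)cc1`: in this assay compound 3 gives 144 nM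

Compound 1 and compound 3 share one core, while compound 2 is built on another; the difference between the two cores is not broken down here. Compound 3 differs from compound 1 in a single place: (1,2,3,4-tetrahydronaphthalen-1-yl)amino in place of 1,2,3,4-tetrahydroisoquinolin-2-yl on a carbonyl carbon. That change gave a 3.7-fold lower number from compound 1 to compound 3 (0.57 log units; beyond the scatter). Among the three, compound 2 gives the lowest number, beyond the scatter from both others.

Compound 4, `CC#CC(CC(=O)O)c1ccc(OCc2ccc(C(=O)NC3CCCc4ccccc43)o2)cc1`, has not been measured. It arises from compound 2 by the same change, at the same place: (1,2,3,4-tetrahydronaphthalen-1-yl)amino in place of 1,2,3,4-tetrahydroisoquinolin-2-yl on a carbonyl carbon. Among the measured compounds shown here, the only guide to its effect is the one earlier step, which was modest but beyond the scatter. The step from compound 2 to compound 4 is expected to be of similar size, a 2.9-fold lower number from compound 2 to compound 4 (0.47 log units; beyond the scatter), because on the other core the same change gave a 3.7-fold lower number from compound 1 to compound 3 (0.57 log units; beyond the scatter). Whether the second core carries the change equally well cannot be told from three compounds. Compound 4 is therefore estimated at 17 nM in this assay, most likely between 6 nM and 50 nM.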

Compound 4, half-maximal effective concentration: 133 nM
Compound 4: the middle estimate sits 7.8-fold (0.89 log units) below what was measured, and the stated range ends below it.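

In this assay, putting (1,2,3,4-tetrahydronaphthalen-1-yl)amino in place of 1,2,3,4-tetrahydroisoquinolin-2-yl on the carbonyl carbon gave a 2.7-fold higher number from compound 2 to compound 4 (0.42 log units; beyond the scatter), so the number went up on this core, whereas the same change lowered it on the core of compound 1. The two steps run in opposite directions and clearly differ, so in this series the result of the change on one core did not predict its result on the other: the same change on two cores in this assay, a 3.7-fold lower number (0.57 log units; beyond the scatter) from compound 1 to compound 3 and a 2.7-fold higher number (0.42 log units; beyond the scatter) from compound 2 to compound 4, 9.8-fold (0.99 log units) apart, beyond the scatter of two such steps This rests on just one pair of compounds per core, and it does not show which part of the cores is responsible or why the direction reverses.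

The compounds shown leave open whether other groups on the carbonyl carbon, such as benzylamino or cyclohexylamino, would also behave differently on the two cores. They also leave open what would happen on each core if the amide hydrogen of compound 3 and compound 4 were replaced by a methyl group.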